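Swapping a Fluorophenyl for a Furan on Two Cores

A few compounds are considered here, and "the series" means these few. Any claim that something is new, unique, unknown or untested is made for them only; others in the source may bear on it.

Of the compounds shown here, three have been measured in a functional assay on MCF7 cells (Homo sapiens) for inhibition, with a stated time of 72 h; a higher number here means a weaker inhibitor, a lower number a stronger inhibitor. Compound 1 `NC1CCC(Nc2nc(NCc3ccc(-c4cccc(F)c4)cc3)c3ncn(C4CCCC4)c3n2)CC1` gives 293 nM. Compound 2 `NC1CCC(Nc2nc(NCc3ccc(-c4ccco4)cc3)c3ncn(C4CCCC4)c3n2)CC1` gives 85 nM. Compound 3 `NC1CCC(Nc2nc(NCc3ccc(-c4cccc(F)c4)nc3)c3ncn(C4CCCC4)c3n2)CC1` gives 33 nM, the lowest of the three numbers.

Compound 1 and compound 2 differ in one place: furan-2-yl in place of 3-fluorophenyl on an aromatic carbon. This change made a step of a 3.4-fold lower number from compound 1 to compound 2 (0.54 log units; beyond the scatter) in this assay. Compound 3 and compound 1 share most of their structure, but the difference between the two cores is not broken down here.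

Compound 4 `NC1CCC(Nc2nc(NCc3ccc(-c4ccco4)nc3)c3ncn(C4CCCC4)c3n2)CC1` has not yet been measured. It differs from compound 3 in one place: furan-2-yl in place of 3-fluorophenyl on an aromatic carbon. This is the same kind of change as that from compound 1 to compound 2, though its surroundings are not identical: in compound 3 the group sits on a six-membered aromatic ring with 1 nitrogen, next to the ring nitrogen, whereas in compound 1 the ring is of carbon only; in both cases the group stands para to a large group.

Because the earlier step was a 3.4-fold lower number from compound 1 to compound 2 (0.54 log units; beyond the scatter), a step of similar direction is expected here, estimated at a 2.5-fold lower number from compound 3 to compound 4 (0.40 log units; beyond the scatter) in this assay, with some caution because the ring that carries the group is not the same. Compound 4 is therefore expected to give about 13 nM, most likely between 5 nM and 35 nM.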

Compound 4, half-maximal inhibitory concentration: 33 nM
Beside the measured number, compound 4's estimate is 2.5-fold (0.40 log units) below it, and the stated range covers the measured number.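

In this assay, the swap of 3-fluorophenyl for furan-2-yl did not carry over unchanged from one core to the other: the same change on two cores in this assay, a 3.4-fold lower number (0.54 log units; beyond the scatter) from compound 1 to compound 2 and no change at the digits printed (within the scatter) from compound 3 to compound 4, 3.4-fold (0.54 log units) apart, beyond the scatter of two such steps

On the core whose ring holds a nitrogen, the swap gave no change at the digits printed from compound 3 to compound 4 (within the scatter), whereas keeping furan-2-yl and changing the core gave a 2.6-fold lower number from compound 2 to compound 4 (0.41 log units; beyond the scatter), so the effect of the group depends on the core it sits on in these four compounds. Among these compounds, this does not show why the two steps differ, and with only one pair on each core it gives no general rule for how this swap behaves across the series.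

The compounds shown leave open whether a different group in the same place, such as an amine or a carboxylic acid, would also respond differently on the two cores. They also leave open whether the same gap between the two steps would appear with other groups on the shared core, such as a longer chain in place of the cyclopentyl group.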